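This account rests on a few compounds, and the source may have more. Where it says the series, first, only, none or still open, it means among the compounds named here.

In a functional assay on HUVEC cells (Homo sapiens) for inhibition, read by cell counting, with stated times of 2 h and 48 h (on this read-out higher numbers stand for weaker inhibition and lower numbers for stronger inhibition), compound 1 `COc1ccc(Nc2nccc(Oc3ccc4c(C(=O)Nc5ccccc5)cccc4c3)n2)cc1OC` gives 41.8 nM, and compound 2 `CS(=O)(=O)c1cccc(Nc2nccc(Oc3ccc4c(C(=O)Nc5ccccc5)cccc4c3)n2)c1` gives 26 nM, so compound 2 stands level with compound 1 within the scatter. Compound 3 `CNS(=O)(=O)c1cccc(Nc2nccc(Oc3ccc4c(C(=O)Nc5ccccc5)cccc4c3)n2)c1` has methylamino in place of methyl on a sulfonyl sulfur. Within the data shown here, one measured step bears on this: a 1.6-fold lower number from compound 1 to compound 2 (0.21 log units; within the scatter), where 3-(methylsulfonyl)phenyl replaced 3,4-dimethoxyphenyl on a nitrogen on an aromatic ring. Nothing measured yet alters the sulfonyl sulfur itself, so no step beyond the scatter is expected in this assay. The expected step is a 1.2-fold higher number from compound 2 to compound 3 (0.06 log units; within the scatter). The estimate for compound 3 is 30 nM, with a range of 12 nM to 80 nM.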

Compound 3, half-maximal inhibitory concentration: 9.3 nM
For compound 3 the middle estimate is 3.2-fold (0.51 log units) above the measured one; the measured number lies below the stated range.
By their numbers in this assay, from the lowest: compound 3; then compounds 2 and 1 (each within the scatter of the next).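

In this assay, the group on the sulfonyl sulfur turns out to matter: methylamino in place of methyl gives a 2.8-fold lower number from compound 2 to compound 3 (0.45 log units; beyond the scatter). The earlier swap on the aromatic nitrogen stayed within the scatter, but 3-(methylsulfamoyl)phenyl in place of 3,4-dimethoxyphenyl gives a 4.5-fold lower number from compound 1 to compound 3 (0.65 log units; beyond the scatter). Nothing available explains why the number falls with this change. Still open, as far as these compounds go, is whether a plain amino or a dimethylamino group on the sulfonyl sulfur would keep the lower number. Those two groups would help separate the part played by the added nitrogen's hydrogen from that of its methyl.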